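Notes on four compounds in the paw edema assay

This account rests on a few compounds, and the source may have more. Where it says the series, first, only, none or still open, it means among the compounds named here.

Measured so far:
Compound 1, `COc1ccc(/C=C/C(=O)c2ccc(NC(=O)CO[N+](=O)[O-])cc2)cc1`: 46%
Compound 2, `O=C(CO[N+](=O)[O-])Nc1ccc(C(=O)/C=C/c2ccco2)cc1`: 39%
Compound 3, `COc1ccc(/C=C/C(=O)c2ccc(NC(=O)COc3ccc(/C(C)=N\O)cc3)cc2)cc1`: 37%

All values come from a functional assay on the whole organism (strain albino) for inhibition, with Rattus norvegicus as the target, read by paw edema, with stated times of 30 min and 5 h, at a dose of 100 mg/kg by the oral route; on this read-out lower numbers stand for less inhibition and higher numbers for more inhibition at the one dose given (going by the name of the read-out). The three numbers sit within the scatter of one another: the step of a number 9 percentage points lower from compound 1 to compound 3 (within the scatter) is within it, and compound 2 and compound 3 give values that do not separate. The cores of compound 1 and compound 3 differ thus: a group of 10 heavy atoms (8 carbon, 1 nitrogen, 1 oxygen; one six-membered aromatic ring of carbon only) in place of a group of 3 heavy atoms (1 nitrogen, 2 oxygen; no ring), on an oxygen on a saturated carbon. The change of interest, (furan-2-yl in place of 4-methoxyphenyl on a double-bonded chain carbon bound to a double-bonded chain carbon), has one measured instance, a number 7 percentage points lower from compound 1 to compound 2 (within the scatter). Compound 4, `C/C(=N/O)c1ccc(OCC(=O)Nc2ccc(C(=O)/C=C/c3ccco3)cc2)cc1`, is not yet measured; it carries the same change on the core of compound 3: furan-2-yl in place of 4-methoxyphenyl on a double-bonded chain carbon bound to a double-bonded chain carbon. For compound 4 the expected step is a number 6 percentage points lower from compound 3 to compound 4 (within the scatter), a small downward movement, because the earlier instance a number 7 percentage points lower from compound 1 to compound 2 (within the scatter) stayed within the scatter. Compound 4 is therefore estimated at 31%, expected between 18% and 44%.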

Compound 4, a percentage reported as inhibition, in the whole organism at one dose (the size of the read-out at that dose, not a potency): 42%
Beside the measured number, compound 4's estimate is 11 percentage points below it; low and high end bracket the measured number.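

In this assay, furan-2-yl in place of 4-methoxyphenyl gives a number 5 percentage points higher from compound 3 to compound 4 (within the scatter), and this step does not separate from the earlier instance: the same change on two cores in this assay, a number 7 percentage points lower (within the scatter) from compound 1 to compound 2 and a number 5 percentage points higher (within the scatter) from compound 3 to compound 4, 12 percentage points apart, within the scatter of two such steps. The exchange of groups on the oxygen on a saturated carbon gives a number 3 percentage points higher from compound 2 to compound 4 (within the scatter), and it too reads alike on both cores: the same change on two cores in this assay, a number 9 percentage points lower (within the scatter) from compound 1 to compound 3 and a number 3 percentage points higher (within the scatter) from compound 2 to compound 4, 12 percentage points apart, within the scatter of two such steps. Carrying either change from one core to another therefore shows no core dependence here, but with every step within the scatter, neither a real effect of the change nor a true transfer of one is shown.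

The compounds shown leave open how an amine or a carboxylic acid in place of furan-2-yl on a double-bonded chain carbon bound to a double-bonded chain carbon would read. A single-dose read-out also leaves potency open.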